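The compounds below may be only part of what the source reports. "The series", "measured", "known", "first", "only" and "open" are said of these compounds alone.

The two measured compounds come from one series built on a shared core. Compound 1 `CCCn1c(SCc2ccc(C(C)(C)C)cc2)nc2c1c(=O)[nH]c(=O)n2C` carries a propyl group and a thioether-linked benzyl substituent, while compound 2 `Cn1cnc2c1c(=O)n(CC(=O)O)c(=O)n2C` bears an acetic acid on the ring nitrogen. In a functional assay on MGC-803 cells (Homo sapiens) for inhibition, read by MTT assay, with a stated time of 48 h, tested at 20 uM (on this read-out higher numbers stand for more inhibition at the one concentration tested (going by the name of the read-out) and lower numbers for less inhibition), compound 1 gives 10.3%. In this assay compound 2 gives 0.8%, a number that sits within the usual scatter of the value of compound 1, so the two compounds cannot be told apart on these data.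

Compound 3 `CN1CCN(C(=O)Cn2c(=O)c3c(ncn3C)n(C)c2=O)CC1` has not been measured in this assay. It differs from compound 2 in one place: 4-methylpiperazin-1-yl in place of hydroxy on a carbonyl carbon. For the measured compounds named here, no step between measured compounds bears on this change, so nothing in the present numbers suggests that it would move the read-out far. Both measured compounds sit low, and the expectation for compound 3 is therefore a step from compound 2 that stays within the scatter, a number 4.2 percentage points higher from compound 2 to compound 3 (within the scatter). Compound 3 is estimated at 5% in this assay, with a range from -5% to 20%.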

Compound 3, a percentage reported as inhibition, at one concentration (the size of the read-out at that concentration, not a potency): 8.6%
Estimate against measurement, compound 3: 3.6 percentage points below, within the range that was stated.
By their numbers in this assay, from the lowest: compounds 2, 3 and 1 (each within the scatter of the next).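

For the compounds shown here, the step is a number 7.8 percentage points higher from compound 2 to compound 3 (within the scatter) in this assay and it is the only comparison that isolates a single change, here on a carbonyl carbon whose other neighbour is a saturated chain carbon. It shows that replacing hydroxy, with its 1 heavy atom and 1 hydrogen-bond donor, by 4-methylpiperazin-1-yl, with its 7 heavy atoms and one six-membered non-aromatic ring, does not separate compound 3 from compound 2 on this read-out, so this large change in the group at this place leaves the two compounds indistinguishable. No other measurement accompanies this step, and the data offer no explanation for the result.

On these data alone, whether another amine on the same carbonyl carbon, such as morpholine or dimethylamine, or a methyl ester in place of hydroxy, would stand apart from compound 2 remains open. Also open, as far as these compounds go, is whether a longer chain between this carbonyl carbon and the shared core would give a step beyond the scatter, and a reading at one concentration says nothing about the potency of compound 3.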